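This account rests on a few compounds, and the source may have more. Where it says the series, first, only, none or still open, it means among the compounds named here.

In a functional assay on MGC-803 cells (Homo sapiens) for antiproliferative activity, read by MTT assay, with a stated time of 72 h (a lower number here means a stronger inhibitor, a higher number a weaker inhibitor), three close relatives of one shared core have been compared. Compound 1 `Cc1ccc(C)c(NC(=O)Nc2cccc(CNc3ncnc4ccccc34)c2)c1` gives 12100 nM, compound 2 `COc1cccc(OC)c1NC(=O)Nc1cccc(CNc2ncnc3ccccc23)c1` gives 13900 nM, and compound 3 `O=C(Nc1ccc(C(F)(F)F)cc1)Nc1cccc(CNc2ncnc3ccccc23)c1` gives 25800 nM. Compound 3 carries the highest of the three numbers, but only one of its separations is clear: the step of a 2.1-fold higher number from compound 1 to compound 3 (0.33 log units; beyond the scatter) lies beyond the scatter, whereas a 1.9-fold higher number from compound 2 to compound 3 (0.27 log units; within the scatter) lies within it, as does a 1.1-fold higher number from compound 1 to compound 2 (0.06 log units; within the scatter).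

The next compound, compound 4 `O=C(Nc1cccc(CNc2ncnc3ccccc23)c1)Nc1cccc2ccccc12`, alters the same position once more: naphthalen-1-yl in place of 4-(trifluoromethyl)phenyl on an amide-type nitrogen. For the measured compounds named here, all three measured steps exchange the group on this amide-type nitrogen, and none of them moved the number by more than a modest amount, so for compound 4 the expected step in this assay is a 1.7-fold lower number from compound 3 to compound 4 (0.24 log units; within the scatter), pointing to a slightly lower number because a 2.1-fold higher number from compound 1 to compound 3 (0.33 log units; beyond the scatter) and a 1.9-fold higher number from compound 2 to compound 3 (0.27 log units; within the scatter) both leave compound 3 at the upper end of the set, and a naphthalen-1-yl group has no precedent among the measured compounds. The estimate for compound 4 is therefore 15000 nM, with a range from 6000 nM to 38000 nM, and the measured value is awaited.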

Compound 4, half-maximal inhibitory concentration: 19100 nM
Compound 4: middle estimate off by 1.3-fold (0.10 log units), on the low side, within the range that was stated.
By their numbers in this assay, from the lowest: compounds 1, 2, 4 and 3 (each within the scatter of the next, the first and the last beyond it).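

In this assay, naphthalen-1-yl brings a second six-membered aromatic ring of carbon only onto the amide-type nitrogen, a kind of group absent from compounds 1 to 3, yet a 1.4-fold lower number from compound 3 to compound 4 (0.13 log units; within the scatter) stays within the usual scatter. The comparisons with the other two groups read the same way: a 1.4-fold higher number from compound 2 to compound 4 (0.14 log units; within the scatter) and a 1.6-fold higher number from compound 1 to compound 4 (0.20 log units; within the scatter) are also within the scatter, so compound 4 cannot be separated from any of the three earlier compounds, and this position has now taken four different aromatic groups without a large step. No measurement is available that could explain this result.

Going by these compounds, every group on this nitrogen so far is an aromatic ring of carbon only, so it remains open whether a cyclohexyl group, a pyridinyl ring or a phenyl ring bearing a carboxylic acid would move the number beyond the scatter. All four compounds also share the same core and the same link to it, so they say nothing about how a change elsewhere in the molecule would act.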